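The compounds below may be only part of what the source reports. "The series", "measured", "known", "first", "only" and "open" are said of these compounds alone.

Measured compounds:
- compound 1, `C=C(CCCC)C(=O)c1ccc(OC(C)C(=O)O)c(C)c1C`: 12100 nM
- compound 2, `C=C(CCC)C(=O)c1ccc(OC(C)C(=O)O)c(C)c1C`: 11200 nM
- compound 3, `C=C(C)C(=O)c1ccc(OC(C)C(=O)O)cc1Br`: > 60000 nM

In a functional assay on HL-60 cells (Homo sapiens) for antiproliferative activity, with a stated time of 72 h (a higher number here means a weaker inhibitor of growth, a lower number a stronger inhibitor of growth), compound 1 stands at the highest of the two numbers shown, with compound 2 within the scatter of it. The value of compound 3 in this assay is a limit of the assay, not a number, and the limit of > 60000 nM in this assay, at which 1 of the 3 values shown sits, is the only such limit here. The unmeasured compound 4, `C=C(CCCC)C(=O)c1ccc(OCC(=O)O)c(C)c1C`, differs from compound 1 by hydrogen in place of methyl on a saturated chain carbon bound to a carbonyl carbon and an oxygen on an aromatic ring. Going by the values given here, no measured step touches that place: the one step available, a 1.1-fold lower number from compound 1 to compound 2 (0.03 log units; within the scatter), alters the chain on the other side of the core and changed nothing beyond the scatter. With no guide for this change, compound 4 is expected to stay close to compound 1, a step of a 1.2-fold higher number from compound 1 to compound 4 (0.09 log units; within the scatter), giving an estimate of 15000 nM, between 5000 nM and 45000 nM.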

Compound 4, concentration for 50% growth inhibition: 14400 nM
Beside the measured number, compound 4's estimate is 1.0-fold (0.02 log units) above it; the range from low to high includes it.
By their numbers in this assay, from the lowest: compounds 2, 1 and 4 (each within the scatter of the next). At a limit, above all of these: compound 3.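

In this assay, replacing 1-carboxyethyl with carboxymethyl gives a 1.2-fold higher number from compound 1 to compound 4 (0.08 log units; within the scatter), the first step shown at this place. The methyl on this saturated chain carbon is therefore not needed for the growth inhibition seen with compound 1, and removing it has no effect that stands out from the scatter. Nothing shown here accounts for this result.

As far as these compounds go, it remains open whether a longer chain on this carbon would shift the number. The same question applies to an amide or an amine in place of the carboxylic acid.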